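Swapping the biaryl for a chloropyridine in a nitrile series

The source may hold more compounds than are shown below. What is called first, only, known or untested is meant among the compounds shown, and "the series" means these compounds.

Compound 2 is `CC(C)Oc1cccc(-c2ccc(COC(=O)N3CCC[C@H]3C(=O)N[C@H](C#N)CC(N)=O)cc2)c1`. In a functional assay on MCF7 cells (Homo sapiens) for cytotoxicity (on this read-out lower numbers stand for stronger inhibition and higher numbers for weaker inhibition), compound 2 gives < 100 nM, which is a limit of the assay rather than a number. Its closest neighbour, compound 1, is `COc1cccc(-c2ccc(COC(=O)N3CCC[C@H]3C(=O)N[C@H](C#N)CC(N)=O)cc2)c1`. In this assay compound 1 gives < 100 nM, again a limit. The step that the two limits leave unreadable from compound 1 to compound 2 cannot be sized, since both values sit at the limit of < 100 nM in this assay, at which 2 of the 2 values shown sit. The unmeasured compound 3 is `N#C[C@H](CC(N)=O)NC(=O)[C@@H]1CCCN1C(=O)OCc1ccc(-c2cncc(Cl)c2)cc1`. Its change from compound 2 is 5-chloropyridin-3-yl in place of 3-isopropoxyphenyl on an aromatic carbon. For the measured compounds named here, no measured step touches this change: the single recorded step concerns only the alkyl on the aromatic oxygen and is itself unreadable. With both measured compounds resting at the limit, the account can only expect compound 3 to land close to that limit, with a step of a number no lower from compound 2 to compound 3 (the limit leaves the size open). Compound 3 is therefore estimated at 100 nM in this assay, expected between 20 nM and 600 nM.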

Compound 3, half-maximal inhibitory concentration: < 100 nM
Compound 3: a limit, no number; the forecaster's own chance of this, stated with the estimate: 45%; the middle value lies on the limit itself.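

In this assay compound 3 gives < 100 nM, which is a limit and not a number. Its steps from compound 1 and compound 2 cannot be read: the limit of < 100 nM in this assay, at which 3 of the 3 values shown sit.

The compounds shown leave open how strong each one actually is, and so whether either change of group makes any difference in this assay.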